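The source may hold more compounds than are shown below. What is called first, only, known or untested is meant among the compounds shown, and "the series" means these compounds.

Compound 1 `CC(=O)NCc1cccc(Cn2nc(NS(=O)(=O)c3ccc(Cl)s3)c3c(Cl)cccc32)c1`: 6310 nM
Compound 2 `CC(=O)NCc1cccc(Cn2nc(NS(=O)(=O)c3ccc(Cl)s3)c3c(O)cccc32)c1`: 794 nM
Compound 3 `CC(=O)NCc1cccc(Cn2nc(NS(=O)(=O)c3ccc(Cl)s3)c3c(CO)cccc32)c1`: 1000 nM

The three compounds share a core and differ only in one group on the fused aromatic ring. In an assay on isolated protein (blood) for antagonist activity at C-C chemokine receptor type 4 (Homo sapiens), read by flow cytometry, with a stated time of 30 min (a lower number here means tighter binding, a higher number weaker binding), compound 2 gives the lowest of the three numbers. Its nearest neighbour is compound 3; the step of a 1.3-fold higher number from compound 2 to compound 3 (0.10 log units; within the scatter) lies within the scatter, so the two cannot be ranked against each other. Compound 1 sits furthest away, with a 7.9-fold lower number from compound 1 to compound 2 (0.90 log units; beyond the scatter) and a 6.3-fold lower number from compound 1 to compound 3 (0.80 log units; beyond the scatter) both beyond the scatter.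

Compound 4 `CC(=O)NCc1cccc(Cn2nc(NS(=O)(=O)c3ccc(Cl)s3)c3c(C(C)O)cccc32)c1` has not yet been measured. It differs from compound 2 by 1-hydroxyethyl in place of hydroxy on an aromatic carbon. Within the data shown here, the step that bears most directly on this change is the one from compound 2 to compound 3, where a hydroxy was also replaced by a carbon-bearing alcohol and the number hardly moved. Adding one more carbon in the same way is therefore expected to give no step beyond the scatter in this assay. The expected step is a 1.1-fold higher number from compound 2 to compound 4 (0.05 log units; within the scatter). Compound 4 is estimated at 900 nM, with a range from 300 nM to 2700 nM.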

Compound 4, dissociation constant: 501 nM
The estimate for compound 4 lay 1.8-fold (0.25 log units) above the measured number, and the stated range covers the measured number.
By their numbers in this assay, from the lowest: compounds 4, 2 and 3 (each within the scatter of the next); then compound 1.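

In this assay, this position on the fused aromatic ring accepts the branched 1-hydroxyethyl group: a 1.6-fold lower number from compound 2 to compound 4 (0.20 log units; within the scatter) and a 2.0-fold lower number from compound 3 to compound 4 (0.30 log units; within the scatter) both stay within the scatter, so neither the swap from hydroxy, with 3 heavy atoms entering for 1, nor the added methyl can be told from no change. Replacing chloro gives a 13-fold lower number from compound 1 to compound 4 (1.10 log units; beyond the scatter), which is large, so compounds 2, 3 and 4 all stand apart from compound 1 and cannot be ranked among themselves. No measurement here explains what separates these groups from chloro.

A plain ethyl, a methoxy or an aminomethyl group at this place would test whether the alcohol itself is what sets these compounds apart from compound 1. Going by these compounds, how much further the group can grow also stays open, for instance with a longer chain such as 1-hydroxypropyl.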